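Furoyl Ester in Place of the Basic Side Chain

The compounds below may be only part of what the source reports. "The series", "measured", "known", "first", "only" and "open" are said of these compounds alone.

Compound 1 `C#CCOc1cc(/C=C/C(=O)c2ccc(OC)c3c2OC(C)(C)C=C3)ccc1OC` gives in a functional assay on A-375 cells (Homo sapiens) for cytotoxicity, read by MTT assay (a lower number here means a stronger inhibitor, a higher number a weaker inhibitor), only > 10000 nM, which is a limit of the assay and not a number: the limit of > 10000 nM in this assay, at which 1 of the 2 values shown sits. Among the compounds with values here, compound 2 `COc1ccc(/C=C/C(=O)c2ccc(OC)c3c2OC(C)(C)C=C3)cc1OCCCN(C)C` is the only compound of the pair with a real number in this assay, where compound 2 gives 4100 nM. Within the data shown here, the single measured step, an at least 2.4-fold lower number from compound 1 to compound 2 (0.38 log units; beyond the scatter), is all the evidence available. Compound 3 `COc1ccc(/C=C/C(=O)c2ccc(OC)c3c2OC(C)(C)C=C3)cc1OC(=O)c1ccco1` differs from compound 2 in one place: (furan-2-yl)carbonyl in place of 3-(dimethylamino)propyl on an oxygen on an aromatic ring. Among the measured compounds shown here, that change has no measured counterpart; it removes the very group whose arrival marked the one step and brings in an ester rather than an ether. The number is therefore expected to move back toward the limit, by a 2.0-fold higher number from compound 2 to compound 3 (0.29 log units; within the scatter). Compound 3 is thus estimated at 8000 nM, with a range of 2500 nM to 25000 nM.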

Compound 3, half-maximal inhibitory concentration: 680 nM
Beside the measured number, compound 3's estimate is 12-fold (1.07 log units) above it; the whole stated range lies above it.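

With (furan-2-yl)carbonyl in place of 3-(dimethylamino)propyl on this oxygen, this assay shows a 6.0-fold lower number from compound 2 to compound 3 (0.78 log units; beyond the scatter), so the amine present in the earlier measured step is not required for a measurable number here, and an ester gives a lower number than that ether. Set against the propargyl group, the same ester gives an at least 14-fold lower number from compound 1 to compound 3 (1.16 log units; beyond the scatter). This step is open-ended, since compound 1 stands at a limit of the assay and not at a number: the limit of > 10000 nM in this assay, at which 1 of the 3 values shown sits.

The compounds shown leave open whether the lower number belongs to the furan ring or to the carbonyl, which a benzoyl or acetyl ester and a furan-2-ylmethyl ether on the same oxygen would help to separate. Also open, going by these compounds, is how a thiophene-2-carbonyl group or a carbamate would read in this assay.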